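Fluoro Replaces Bromo After a Large Drop

The compounds below may be only part of what the source reports. "The series", "measured", "known", "first", "only" and "open" are said of these compounds alone.

In a functional assay on A549 cells (Homo sapiens) for inhibition, read by CCK-8 assay, with a stated time of 72 h, tested at 8 uM (a higher number here means more inhibition of growth at the concentration tested, a lower number less inhibition of growth), compound 1 (`Cc1ccc(SCc2ccc(C(=O)Nc3ccccc3N)cc2)cc1`) gives 78.3% of growth inhibition. Compound 2 (`Nc1ccccc1NC(=O)c1ccc(CSc2ccc(Br)cc2)cc1`) gives 45.7% and so stands lowest of the two compounds measured. Going by the values given here, the only measured step is bromo in place of methyl on an aromatic carbon (a number 32.6 percentage points lower from compound 1 to compound 2 (beyond the scatter)). Compound 3 (`Nc1ccccc1NC(=O)c1ccc(CSc2ccc(F)cc2)cc1`) carries fluoro in place of bromo on that aromatic carbon, para to a large group (fluoro in place of bromo on an aromatic carbon). Among the compounds with values here, the measured step bears on this change only in part: it shows that a swap at this place can move the number by a large amount, but no measured compound carries fluoro. A moderate rise is expected, recovering part of that drop, and the estimate is a number 14.3 percentage points higher from compound 2 to compound 3 (beyond the scatter) with real uncertainty. The estimated value for compound 3 is 60% with an expected range from 40% to 80% in this measurement.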

Compound 3, percent growth inhibition at one concentration: 44.5%
Beside the measured number, compound 3's estimate is 15.5 percentage points above it; measured number inside the range.
By their numbers in this assay, from the lowest: compounds 3 and 2 (each within the scatter of the next); then compound 1.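

In this assay, exchanging one halogen for the other at this place on the ring leaves no difference that can be told from the scatter, the step reading a number 1.2 percentage points lower from compound 2 to compound 3 (within the scatter). The earlier compounds tied the large gap to bromo alone, whereas the new step, a number 33.8 percentage points lower from compound 1 to compound 3 (beyond the scatter), shows that fluoro stands well under methyl as well, so among these three compounds the gap is not particular to bromo and methyl alone stands apart. No measurement offered here accounts for this.

Going by these compounds, whether the high number belongs to methyl alone or extends to other groups on this aromatic carbon remains open, for only methyl, bromo and fluoro appear there. An ethyl group, a methoxy group or an amine at the same place would test this.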